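The compounds below may be only part of what the source reports. "The series", "measured", "known", "first", "only" and "open" are said of these compounds alone.

Three compounds sharing one core were tested in a functional assay on the whole organism (Tail, strain ICR) with Mus musculus as the target, in the tail flick test, with a stated time of 150 min, at a dose of 25 umol/kg by the oral route; a higher number here means a stronger effect of the compound at the dose given, a lower number a weaker effect. Compound 1, `N=C(N)NCCC[C@H](NC(=O)CN(c1nc(Cl)nc2[nH]cnc12)C1CC1)C(=O)O`, gives 7.19% and stands second highest of the three numbers. Compound 2, `N=C(N)NCCC[C@H](NC(=O)CN(c1nc(Cl)nc2[nH]cnc12)C1CC1)C(=O)OCc1ccccc1`, gives 6.12%; the step of a number 1.1 percentage points lower from compound 1 to compound 2 (within the scatter) shows that the benzyl ester hardly mattered. Compound 3, `O=C(CN(c1nc(Cl)nc2[nH]cnc12)C1CC1)N[C@@H](CCC(=O)OCc1ccccc1)C(=O)OCc1ccccc1`, gives 44.5%, reached through a number 38.4 percentage points higher from compound 2 to compound 3 (beyond the scatter). Compound 4, `NCCCC[C@H](NC(=O)CN(c1nc(Cl)nc2[nH]cnc12)C1CC1)C(=O)O`, has not yet been measured; it differs from compound 1 by a group of 2 heavy atoms (1 carbon, 1 nitrogen; no ring) in place of a group of 4 heavy atoms (1 carbon, 3 nitrogen; no ring), on a saturated chain carbon, four bonds along the chain from an amide-type nitrogen and a carbonyl carbon. Within the data shown here, no measured step makes this swap. Among the measured compounds shown here, the only step that touches the same chain, from compound 2 to compound 3, was large, but it brings in a much bigger group with an aromatic ring, so it offers little guidance here. Compound 4 is therefore expected to change little, a number 1.8 percentage points higher from compound 1 to compound 4 (within the scatter), with an estimated 9% between 0% and 25%.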

Compound 4, a percentage reported as activity, at one dose (the size of the read-out at that dose, not a potency): 11.6%
Beside the measured number, compound 4's estimate is 2.6 percentage points below it; the range from low to high includes it.
By their numbers in this assay, from the lowest: compounds 2, 1 and 4 (each within the scatter of the next); then compound 3.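

In this assay, aminomethyl in place of the group of 4 heavy atoms, on a saturated chain carbon, four bonds along the chain from an amide-type nitrogen and a carbonyl carbon, gives a number 4.4 percentage points higher from compound 1 to compound 4 (within the scatter). Among these compounds, at this position, then, the two groups cannot be told apart in this test, so the large rise seen with compound 3 has no counterpart in this swap. Nothing measured here explains this result. Still open, going by these compounds, is how a carboxylic acid at the chain end, or a longer chain ending in an amine, would compare. Also open, on these data alone, is whether a benzyl ester on compound 4 would change its number.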